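Fluoro for Methoxy in an Amide Series Without Measurable Cytotoxicity

A few compounds are considered here, and "the series" means these few. Any claim that something is new, unique, unknown or untested is made for them only; others in the source may bear on it.

Compound 1 `C=CC1=C(C(=O)NCCCCC)C(c2ccc(F)cc2)OC1` in a functional assay on A549 cells (Homo sapiens) for cytotoxicity, read by MTT assay, with a stated time of 24 h (on this read-out lower numbers stand for stronger inhibition and higher numbers for weaker inhibition), gives > 100000 nM.
Compound 2 `C=CC1=C(C(=O)NC2CCCCC2)C(c2ccc(F)cc2)OC1` in this assay gives > 100000 nM.
Compound 3 `C=CC1=C(C(=O)NCc2ccccc2)C(c2ccc(OC)cc2)OC1` in this assay gives > 100000 nM.

The value of compound 1 is a limit of the assay, not a measured number. The value of compound 2 is likewise a limit. The value of compound 3 is also a limit. Among the compounds with values here, because of this, the only step between measured neighbours, a step that the two limits leave unreadable from compound 1 to compound 2, cannot be read: both ends sit at the edge of what the assay reports. Compound 3 therefore stands at the limit of > 100000 nM in this assay, at which 3 of the 3 values shown sit, with nothing to rank it against the other two.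

Compound 4 `C=CC1=C(C(=O)NCc2ccccc2)C(c2ccc(F)cc2)OC1` arises from compound 3 by fluoro in place of methoxy on an aromatic carbon. Within the data shown here, no measured step touches this part of the shared core, so there is no direct precedent for the change in this assay. Among the measured compounds shown here, the one step that was measured concerns a different part of the molecule and is unreadable. With all three measured compounds at the limit, compound 4 is expected to remain there too, and the expected step that the limit leaves unreadable from compound 3 to compound 4 is none that the assay could show. The estimate for compound 4 is 200000 nM, with a range from 80000 nM to 1000000 nM.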

Compound 4, half-maximal inhibitory concentration: > 100000 nM
Compound 4: only a limit was reported (the forecaster's own chance of this, stated with the estimate: 85%); the middle value lies beyond the limit too.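

Compound 4 also gives only a limit of the assay in this assay, so its steps from compound 1, compound 2 and compound 3 cannot be read: the limit of > 100000 nM in this assay, at which 4 of the 4 values shown sit.

The compounds shown leave open how these four rank against one another, and whether any change at the amide nitrogen or on the aromatic ring would give a measurable value in this assay.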